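The source may report more compounds than this note shows. Statements on the series, on what has been measured and on what is new or still open speak of the compounds shown alone.

Measured so far: compound 2 `ClCc1ccccc1Cn1cnc2c(Cl)nc(Cl)nc21`, giving 2400 nM in a functional assay on A498 cells (Homo sapiens) for cytotoxicity, read by sulforhodamine B assay, with a stated time of 48 h; a higher number here means a weaker inhibitor of growth, a lower number a stronger inhibitor of growth; compound 1 `ClCc1ccc(Cn2cnc3c(Cl)ncnc32)cc1`, giving 12900 nM in this assay.

Compound 2 holds the lower of the two numbers, and the gap to compound 1 lies beyond the scatter. Compound 3 `ClCc1ccccc1Cn1cnc2c(Cl)ncnc21` has not yet been measured. It differs from compound 2 by hydrogen in place of chloro on an aromatic carbon. Within the data shown here, no single-change pair has been measured, so the size of this step is open. Compound 3 is expected to give a somewhat higher number, estimated as 6000 nM with a range of 2000 nM to 20000 nM, which means a step of a 2.5-fold higher number from compound 2 to compound 3 (0.40 log units; beyond the scatter).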

Compound 3, concentration for 50% growth inhibition: 17400 nM
Compound 3: middle estimate off by 2.9-fold (0.46 log units), on the low side, within the range that was stated.
By their numbers in this assay, from the lowest: compound 2; then compounds 1 and 3 (each within the scatter of the next).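

In this assay the exchange of chloro for hydrogen on the aromatic carbon between two ring nitrogen atoms gives the first single-change step, a 7.3-fold higher number from compound 2 to compound 3 (0.86 log units; beyond the scatter), a step beyond the scatter. At this position, then, chloro goes with stronger growth inhibition than hydrogen. Nothing available accounts for the size of this step.

Going by these compounds, only chloro and hydrogen are compared on this carbon, so whether an amine or a methoxy group there would match chloro remains open. On these data alone, whether the same exchange would have a similar effect on the core of compound 1 is also open.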